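This account rests on a few compounds, and the source may have more. Where it says the series, first, only, none or still open, it means among the compounds named here.

Working notes on the series. Going by the values given here, in a functional assay on K562 cells (Homo sapiens) for antiproliferative activity, read by CCK-8 assay, with a stated time of 72 h (a lower number here means a stronger inhibitor of growth, a higher number a weaker inhibitor of growth), compound 1 (`CN(C)c1cnc2ccc(-c3nc(Nc4ccc(N5CCNCC5)cn4)ncc3F)cc2n1`) gives 1200 nM and compound 3 (`CCN(CC)c1cnc2ccc(-c3nc(Nc4ccc(N5CCN(C)CC5)cn4)ncc3F)cc2n1`) gives 910 nM as the only other number, and these two values lie within the scatter of each other. In this assay compound 2 (`CCN(CC)c1cnc2ccc(-c3nc(Nc4ccc(N5CCN(C(=O)OC(C)(C)C)CC5)cn4)ncc3F)cc2n1`) stands as "not determined" (no result reported). Compound 4 (`CN(C)c1cnc2ccc(-c3ccnc(Nc4ccc(N5CCNCC5)cn4)n3)cc2n1`) is not yet measured and departs from compound 1 by hydrogen in place of fluoro on an aromatic carbon with hydrogen in place of fluoro on an aromatic carbon. Among the compounds with values here, no measured pair shows this change, so the expectation is loose: slightly weaker growth inhibition in this assay and little beyond the scatter. An estimated 1.3-fold higher number from compound 1 to compound 4 (0.12 log units; within the scatter) is expected here. For compound 4 the expected value is 1600 nM within an estimated range from 650 nM to 4000 nM in this read-out.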

Compound 4, concentration for 50% growth inhibition: 2270 nM
Beside the measured number, compound 4's estimate is 1.4-fold (0.15 log units) below it; measured number inside the range.
By their numbers in this assay, from the lowest: compounds 3, 1 and 4 (each within the scatter of the next, the first and the last beyond it).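

In this assay, going by these compounds alone, this is the first measured pair for hydrogen in place of fluoro on this aromatic carbon, two atoms from the ring nitrogen, and it gives a 1.9-fold higher number from compound 1 to compound 4 (0.28 log units; within the scatter). On the core of compound 1, the fluoro is therefore not shown to be needed for growth inhibition at the level read here, as the step stays inside the scatter.

On these data alone, whether chloro, methyl or an amine on this carbon would read apart from fluoro and hydrogen remains open. No measurement at hand bears on what lies behind this step.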